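Tert-butyl in place of 1-methyl-1H-imidazol-2-yl

The source may hold more compounds than are shown below. What is called first, only, known or untested is meant among the compounds shown, and "the series" means these compounds.

In an ADME assay on CHO cells (Cricetulus griseus) for cytotoxicity, read by MTT assay (a higher number here means that more compound is tolerated, a lower number that less compound is tolerated), compound 1 `Fc1cc(F)cc(-c2nc3c(N4CCC(CN5CCNCC5)CC4)nccc3[nH]2)c1` gives 20000 nM and compound 2 `Cn1ccnc1N1CCN(CC2CCN(c3nccc4[nH]c(-c5cc(F)cc(F)c5)nc34)CC2)CC1` gives 33000 nM with the two values within the scatter of each other. Compound 3 `CC(C)(C)N1CCN(CC2CCN(c3nccc4[nH]c(-c5cc(F)cc(F)c5)nc34)CC2)CC1` differs by tert-butyl in place of 1-methyl-1H-imidazol-2-yl on an amine nitrogen in a ring with tert-butyl in place of 1-methyl-1H-imidazol-2-yl on an amine nitrogen in a ring. Among the compounds with values here, the only measured step at this place is a 1.7-fold higher number from compound 1 to compound 2 (0.22 log units; within the scatter) and it stays within the scatter, so no step beyond the scatter is expected in this assay here. The estimated step is a 1.3-fold lower number from compound 2 to compound 3 (0.12 log units; within the scatter) on this single precedent. Compound 3 is estimated at 25000 nM with an expected range of 10000 nM to 60000 nM for this measurement.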

Compound 3, half-maximal cytotoxic concentration in the CHO assay: 8600 nM
Beside the measured number, compound 3's estimate is 2.9-fold (0.46 log units) above it, outside the stated range (below it).
By their numbers in the CHO assay, from the lowest: compound 3; then compounds 1 and 2 (each within the scatter of the next).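

In the CHO assay compound 3 with tert-butyl on this amine nitrogen in a ring gives 8600 nM and this change gives a 3.8-fold lower number from compound 2 to compound 3 (0.58 log units; beyond the scatter) and a 2.3-fold lower number from compound 1 to compound 3 (0.37 log units; beyond the scatter) while compound 1 with hydrogen gives 20000 nM and compound 2 with 1-methyl-1H-imidazol-2-yl at the same place gives 33000 nM and these two values lie within the scatter of each other. In a physicochemical assay for solubility, read by HPLC, using the shake flask method, in phosphate buffer, with a stated time of 20 h, at pH 6.5 (a higher number here means a more soluble compound, a lower number a less soluble compound), compound 2 gives 135000 nM and compound 3 gives 185000 nM and the same change gives a 1.4-fold higher number from compound 2 to compound 3 (0.14 log units; within the scatter) so the two assays do not move together at this position. Nothing available explains the difference.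

Open, on these data alone, is whether this lower number is particular to tert-butyl or also appears with methyl, isopropyl or an acetyl group on this nitrogen.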